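Swapping a bridged amine for diethylamino at the quinoline nitrogen's neighbour

This account rests on a few compounds, and the source may have more. Where it says the series, first, only, none or still open, it means among the compounds named here.

Measured compounds:
compound 1, `CC(C)C(=O)NC1CCN(c2ccc3cc(NC(=O)CCc4ccc(C(F)(F)F)cc4)ccc3n2)C1`, 1 nM in an assay on isolated protein for displacement of a labelled ligand from melanin-concentrating hormone receptor 1 (Homo sapiens); on this read-out lower numbers stand for stronger inhibition and higher numbers for weaker inhibition
compound 2, `O=C(CCc1ccc(C(F)(F)F)cc1)Nc1ccc2nc(N3CC4CCC3CC4)ccc2c1`, 3 nM in this assay

Within the data shown here, compound 2 gives the higher of the two numbers measured so far; the step of a 3.0-fold higher number from compound 1 to compound 2 (0.48 log units; beyond the scatter) separates it from compound 1 and lies beyond the scatter.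

Compound 3, `CCN(CC)c1ccc2cc(NC(=O)CCc3ccc(C(F)(F)F)cc3)ccc2n1`, is not yet measured. It differs from compound 2 by a group of 5 heavy atoms (4 carbon, 1 nitrogen; no ring) in place of a group of 8 heavy atoms (7 carbon, 1 nitrogen; 2 six-membered non-aromatic rings with 1 hetero atom each), on an aromatic carbon.

Among the measured compounds shown here, only one measured step touches this position, the step of a 3.0-fold higher number from compound 1 to compound 2 (0.48 log units; beyond the scatter), which shows that altering the group there changes the number only modestly. For the measured compounds named here, no measured pair shows the exchange of a ring-bearing amine for an open-chain one, so the direction is uncertain. Compound 3 is expected to sit a little higher than compound 2, a step of a 3.3-fold higher number from compound 2 to compound 3 (0.52 log units; beyond the scatter), because the step of a 3.0-fold higher number from compound 1 to compound 2 (0.48 log units; beyond the scatter) already moved that way. Compound 3 is therefore estimated at 10 nM, within 2 nM to 50 nM.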

Compound 3, half-maximal inhibitory concentration: 88 nM
Compound 3: the middle estimate sits 8.8-fold (0.94 log units) below what was measured; the whole stated range lies below it.
By their numbers in this assay, from the lowest: compound 1; then compound 2; then compound 3.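

In this assay, among these compounds, the group on the aromatic carbon next to the ring nitrogen matters far more than the first pair of compounds suggested: putting diethylamino in place of the two-ring amine gives a 29-fold higher number from compound 2 to compound 3 (1.47 log units; beyond the scatter) and this is a large step. Putting diethylamino in place of 3-((isopropylcarbonyl)amino)pyrrolidin-1-yl gives an 88-fold higher number from compound 1 to compound 3 (1.94 log units; beyond the scatter) so at this position both ring-bearing amines shown give lower numbers than the open-chain amine. Nothing available here explains why the open-chain amine gives so much weaker inhibition.

On these data alone, it remains open whether dimethylamino, or a plain pyrrolidin-1-yl without the side amide, would stay close to compound 2 or move towards compound 3. Also open, as far as these compounds go, is whether the same gap would hold if the trifluoromethyl group were exchanged for a chlorine atom.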